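Swapping the Para Group on a Long-Chain Anilide

A few compounds are considered here, and "the series" means these few. Any claim that something is new, unique, unknown or untested is made for them only; others in the source may bear on it.

Measured compounds in an assay on isolated protein (Mus musculus) for inhibition of IL15-IL15 receptor (Homo sapiens), read by resazurin assay, with stated times of 30 min and 2.5 days; on this read-out higher numbers stand for weaker inhibition and lower numbers for stronger inhibition:
compound 1 `Cn1c(Cc2nn(C)c(=O)c3ccccc23)nnc1SCCCCCC(=O)Nc1ccc(Cl)cc1Cl` gives 4100 nM
compound 2 `Cn1c(Cc2nn(C)c(=O)c3ccccc23)nnc1SCCCCCCCC(=O)Nc1ccc(I)cc1` gives 1300 nM
compound 3 `Cn1c(Cc2nn(C)c(=O)c3ccccc23)nnc1SCC(=O)Nc1ccc(O)cc1` gives "not active" (no number reported)

Of the compounds shown here, three built on one shared core have been tested in this assay. Among the two with a reported number, compound 2 gives the lower one at 1300 nM. Its nearest neighbour is compound 1, and the step of a 3.2-fold lower number from compound 1 to compound 2 (0.50 log units; beyond the scatter) is beyond the scatter. That step, however, alters the length of the chain and the groups on the aromatic ring at the same time, so it does not show what the aromatic group alone contributes. Compound 3 has a much shorter chain and a different aromatic group, and for compound 3 the result is simply "not active" (no number reported), with no number attached.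

Compound 4 `CC(C)Oc1ccc(NC(=O)CCCCCCCSc2nnc(Cc3nn(C)c(=O)c4ccccc34)n2C)cc1` is compound 2 with one change: isopropoxy in place of iodo on an aromatic carbon. Going by the values given here, no measured step changes only the group on this ring, so there is no direct guide for this swap. Since compound 2 gives 1300 nM, compound 4 is expected to land close to it, and the step of a 1.4-fold higher number from compound 2 to compound 4 (0.14 log units; within the scatter) is expected to stay within the usual scatter. The estimate for compound 4 is therefore 1800 nM, with a range from 600 nM to 6000 nM.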

Compound 4, half-maximal inhibitory concentration: 1100 nM
Compound 4: the middle estimate sits 1.6-fold (0.21 log units) above what was measured, within the range that was stated.
By their numbers in this assay, from the lowest: compounds 4 and 2 (each within the scatter of the next); then compound 1.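

In this assay the step of a 1.2-fold lower number from compound 2 to compound 4 (0.07 log units; within the scatter) is the first one shown that changes only the group on this ring, with the chain and the shared core left as they were. Iodo has 1 heavy atom and no hydrogen-bond acceptor, while isopropoxy has 4 heavy atoms and 1 hydrogen-bond acceptor, yet the two compounds cannot be told apart on this read-out. On this long-chain anilide, then, the position on the aromatic ring takes the larger isopropoxy group with no change beyond the usual scatter, but no measurement shown here explains this result.

As far as these compounds go, two groups at one position say little about the full range of groups possible there, so it remains open whether an amine or a carboxylic acid in place of iodo would give a similar number. From the compounds shown here alone, the contribution of the chain also remains open, as compound 1 and compound 3 each differ from compound 2 in both the chain and the aromatic group, and comparing the 4-iodophenyl group on a shorter chain would be needed to separate the two effects.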